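Exchanging one ring group: what happens to plasma protein binding?

The source may hold more compounds than are shown below. What is called first, only, known or untested is meant among the compounds shown, and "the series" means these compounds.

- compound 1 `Cc1cn(-c2ccc(Cn3cc(C(=O)O)c(=O)c4c(F)cccc43)cc2)cn1` gives 89.8%
- compound 2 `O=C(O)c1cn(Cc2ccc(-n3ccc4cccnc43)cc2)c2cccc(F)c2c1=O` gives 98.8%

In an ADME assay on a cell-free system (plasma, Homo sapiens) for protein binding, with Plasma (Rattus norvegicus) as the target, compound 1 gives 89.8% and so keeps the larger unbound share of the two measured compounds. Among the compounds with values here, compound 3 `O=C(O)c1cn(Cc2ccc(-n3ccc4cnccc43)cc2)c2cccc(F)c2c1=O` has no measurement yet. Its change from compound 1 is this: a group of 9 heavy atoms (7 carbon, 2 nitrogen; one five-membered aromatic ring with 1 hetero atom, one six-membered aromatic ring with 1 hetero atom) in place of a group of 6 heavy atoms (4 carbon, 2 nitrogen; one five-membered aromatic ring with 2 hetero atoms), on an aromatic carbon on the otherwise shared structure. Within the data shown here, only one measured step bears on it: an 8.5-fold lower unbound fraction from compound 1 to compound 2 (0.93 log units; beyond the scatter) when the same 4-methyl-1H-imidazol-1-yl group leaves. Among the measured compounds shown here, the group entering in compound 2 matches the one in compound 3 in its counted atoms and rings, but the two are not identical. A single step is also thin evidence. A change in the same direction is therefore expected, towards less free compound, though set somewhat short of that step. The expected step is a 3.4-fold lower unbound fraction from compound 1 to compound 3 (0.53 log units; beyond the scatter) in this estimate. For compound 3 the estimated value is 97% with an expected range of 93% to 99.2% in this assay when it is measured.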

Compound 3, plasma protein binding: 98.2%
The estimate for compound 3 lay 1.7-fold (0.22 log units) (unbound fraction) above the measured number; the measured number falls inside the stated range.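

In this assay the group with a five-membered and a six-membered aromatic ring again replaces 4-methyl-1H-imidazol-1-yl, para to a large group, and gives a 5.7-fold lower unbound fraction from compound 1 to compound 3 (0.75 log units; beyond the scatter) in the same direction as the earlier step, so the fall in free compound is not tied to one exact group. The entering groups of compound 2 and compound 3 match in their counted atoms and rings but are not identical, and a 1.5-fold higher unbound fraction from compound 2 to compound 3 (0.18 log units; within the scatter) shows that this difference cannot be told apart from repeat-measurement noise. Nothing measured here explains why plasma protein binding shifts with this exchange.

As far as these compounds go, it remains open whether a simple amine or a carboxylic acid at this place would restore more free compound. The compounds shown also cannot say whether a smaller single ring, such as phenyl, would behave like the imidazole or like the larger groups.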